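Swapping Ethylamino for Dimethylamino on a Shared Core

The source may hold more compounds than are shown below. What is called first, only, known or untested is meant among the compounds shown, and "the series" means these compounds.

Of the compounds shown here, three with a shared core have been measured in a functional assay on HCT-8 cells (Homo sapiens) for antiproliferative activity, read by MTT assay, with a stated time of 48 h; a higher number here means a weaker inhibitor, a lower number a stronger inhibitor. Compound 1 `COc1ccc(C(=O)c2ccc(OC)c3c2C=CC(C)(C)O3)c(NC(=O)CBr)c1`, which carries bromo on the side chain, gives 4360 nM. Compound 2 `CNCC(=O)Nc1cc(OC)ccc1C(=O)c1ccc(OC)c2c1C=CC(C)(C)O2`, with methylamino in that place, gives 3460 nM. Compound 3 `CCNCC(=O)Nc1cc(OC)ccc1C(=O)c1ccc(OC)c2c1C=CC(C)(C)O2`, with ethylamino there, gives 7890 nM. That value stands apart from compound 2 but lies within the scatter of compound 1.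

Compound 4 `COc1ccc(C(=O)c2ccc(OC)c3c2C=CC(C)(C)O3)c(NC(=O)CN(C)C)c1` has not yet been measured. It differs from compound 3 in one place: dimethylamino in place of ethylamino on a saturated chain carbon bound to a carbonyl carbon. This puts dimethylamino in place of ethylamino on a saturated chain carbon bound to a carbonyl carbon.

Among the measured compounds shown here, no measured step makes this exact swap, so the evidence is indirect. The closest is a 2.3-fold higher number from compound 2 to compound 3 (0.36 log units; beyond the scatter), with methyl in place of hydrogen on a saturated chain carbon bound to an amine nitrogen. The two steps away from bromo are smaller: a 1.3-fold lower number from compound 1 to compound 2 (0.10 log units; within the scatter) and a 1.8-fold higher number from compound 1 to compound 3 (0.26 log units; within the scatter). All three steps are small, so no large change is expected here, and compound 4 should fall among the measured values.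

The expected step is a 1.5-fold lower number from compound 3 to compound 4 (0.18 log units; within the scatter), which is none beyond the scatter. For compound 4 the estimated value is 5200 nM, with an expected range from 2600 nM to 10000 nM.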

Compound 4, half-maximal inhibitory concentration: 5660 nM
Estimate against measurement, compound 4: 1.1-fold (0.04 log units) below; the range from low to high includes it.
By their numbers in this assay, from the lowest: compounds 2, 1, 4 and 3 (each within the scatter of the next, the first and the last beyond it).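

In this assay, a 1.4-fold lower number from compound 3 to compound 4 (0.14 log units; within the scatter) shows that rearranging the same heavy atoms on the saturated chain carbon bound to a carbonyl carbon, from ethylamino with 1 hydrogen-bond donor to dimethylamino with 0, moves the number no further than repeat measurements normally do, so this donor count makes no readable difference for this pair. The earlier compounds shown here showed an added methyl only on a saturated chain carbon bound to an amine nitrogen, where a 2.3-fold higher number from compound 2 to compound 3 (0.36 log units; beyond the scatter) went beyond the scatter, while the same group placed on the amine nitrogen itself gives a 1.6-fold higher number from compound 2 to compound 4 (0.21 log units; within the scatter), which stays within it. Dimethylamino also joins methylamino and ethylamino in staying close to the bromo compound, with a 1.3-fold higher number from compound 1 to compound 4 (0.11 log units; within the scatter), so none of the three amino groups shown can be told apart from bromo at this position.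

No measurement shown here explains these small differences. Still open, going by these compounds, is how this position would respond to a larger amine such as diethylamino, a ring amine such as piperidine or morpholine, or a carboxylic acid.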